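The compounds below may be only part of what the source reports. "The series", "measured", "known", "first", "only" and "open" are said of these compounds alone.

In a functional assay on A-375 cells (Homo sapiens) for antiproliferative activity, read by CCK-8 assay, with a stated time of 72 h (on this read-out higher numbers stand for weaker inhibition and lower numbers for stronger inhibition), compound 1 (`CCC(C)n1cnc2c(NCc3ccc(C(=O)Nc4ccccc4N)cc3)nc(Cl)nc21`) gives 2880 nM and compound 2 (`Cc1ccc(Nc2nc(Cl)nc3c2ncn3Cc2ccc(C(=O)Nc3ccccc3N)cc2)cc1`) gives 470 nM, the lower of the two numbers, with a gap beyond the scatter. Within the data shown here, the two compounds differ in more than one place, so no single-change step is available as a guide. Compound 3 (`Nc1ccccc1NC(=O)c1ccc(Cn2cnc3c(Nc4ccccc4)nc(Cl)nc32)cc1`) has hydrogen in place of methyl on an aromatic carbon, para to a large group: hydrogen in place of methyl on an aromatic carbon. Going by these compounds, no change beyond the scatter is expected in this assay, and the direction remains open. The expected size is an estimated step of a 1.1-fold higher number from compound 2 to compound 3 (0.04 log units; within the scatter). Compound 3 is estimated at 520 nM, with an expected range of 210 nM to 1300 nM.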

Compound 3, half-maximal inhibitory concentration: 2800 nM
For compound 3 the middle estimate is 5.4-fold (0.73 log units) below the measured one, and the stated range ends below it.
By their numbers in this assay, from the lowest: compound 2; then compounds 3 and 1 (each within the scatter of the next).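

In this assay the change from (4-methylphenyl)amino to anilino gives a 6.0-fold higher number from compound 2 to compound 3 (0.78 log units; beyond the scatter). Among these compounds, this is the only single-place comparison so far, and it shows that one methyl on an aromatic carbon, para to a large group, can move the number beyond the scatter. No measured evidence bears on the reason for this step.

Whether this step is specific to methyl remains open, since the compounds shown do not reveal how an ethyl, a methoxy or a chlorine at this position would compare. Going by these compounds, the effect of moving the methyl elsewhere on this ring is also open.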